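Swapping the oxetane-bearing oxygen for sulfur on the carbonyl

The source may hold more compounds than are shown below. What is called first, only, known or untested is meant among the compounds shown, and "the series" means these compounds.

Compound 2 `Cc1nc(S(C)(=O)=O)ccc1Oc1ncnc(OC2CCN(C(=O)OC3COC3)CC2)c1F` gives 326 nM in a functional assay on isolated protein for inhibition of Glucose-dependent insulinotropic receptor (Homo sapiens), read by HTRF and cAMP accumulation; a lower number here means that less compound is needed, a higher number that more compound is needed for the effect. Going by the values given here, only one other number exists so far: compound 1 `Cc1nc(S(C)(=O)=O)ccc1Oc1ncnc(OC2CCN(C(=O)O[C@H](C)CF)CC2)c1F` gives 196 nM, and the step of a 1.7-fold higher number from compound 1 to compound 2 (0.22 log units; within the scatter) lies within the scatter, so the two compounds cannot be told apart. Compound 3 `Cc1nc(S(C)(=O)=O)ccc1Oc1ncnc(OC2CCN(C(=O)SC(C)(C)C)CC2)c1F` carries the change ((tert-butyl)sulfanyl in place of (oxetan-3-yl)oxy on a carbonyl carbon). Among the compounds with values here, the single measured step also reshaped the group attached to this carbonyl and stayed within the scatter, so no shift beyond the scatter is expected in this assay. For compound 3 the expected value is 300 nM, within a range from 120 nM to 800 nM, which means an expected step of a 1.1-fold lower number from compound 2 to compound 3 (0.04 log units; within the scatter).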

Compound 3, half-maximal effective concentration: 4.83 nM
Compound 3: the middle estimate sits 62-fold (1.79 log units) above what was measured; the measured number lies below the stated range.
By their numbers in this assay, from the lowest: compound 3; then compounds 1 and 2 (each within the scatter of the next).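

In this assay, the group on this carbonyl carbon matters far more than the earlier pair suggested: (tert-butyl)sulfanyl in place of (oxetan-3-yl)oxy gives a 67-fold lower number from compound 2 to compound 3 (1.83 log units; beyond the scatter), and the same group in place of the fluorine-bearing group gives a 41-fold lower number from compound 1 to compound 3 (1.61 log units; beyond the scatter). The two oxygen-linked groups stay within the scatter of each other, while the sulfur-linked group stands apart from both. Nothing available explains this large step.

The linking atom and the carbon group changed together, and the compounds shown cannot separate the two. On these data alone, how a (tert-butyl)oxy or (tert-butyl)amino group would read at this carbonyl carbon remains open.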